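From pyrazin-2-yl to thiophen-2-yl: compound 3 to compound 4

A few compounds are considered here, and "the series" means these few. Any claim that something is new, unique, unknown or untested is made for them only; others in the source may bear on it.

In a functional assay (blood) for inhibition, with Homo sapiens as the target (on this read-out lower numbers stand for stronger inhibition and higher numbers for weaker inhibition), compound 1 `CC(C)(C)Sc1c(CC(C)(C)C(=O)O)n(Cc2ccc(Cl)cc2)c2ccc(CCc3ccc4ccccc4n3)cc12` reports only a limit, > 3000 nM. Compound 2 `C[C@H](COc1ccc2c(c1)c(SC(C)(C)C)c(CC(C)(C)C(=O)O)n2Cc1ccc(Cl)cc1)c1ccccn1` gives 470 nM, and compound 3 `CC(C)(C)Sc1c(CC(C)(C)C(=O)O)n(Cc2ccc(Cl)cc2)c2ccc(OCc3cnccn3)cc12` gives 400 nM. The step of a 1.2-fold lower number from compound 2 to compound 3 (0.07 log units; within the scatter) lies within the scatter, so compound 3 stands level with compound 2 and neither ranks ahead.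

Compound 4 `CC(C)(C)Sc1c(CC(C)(C)C(=O)O)n(Cc2ccc(Cl)cc2)c2ccc(OCc3cccs3)cc12` carries thiophen-2-yl in place of pyrazin-2-yl on a saturated chain carbon bound to an oxygen on an aromatic ring.

Within the data shown here, no measured step makes this exact exchange. The closest is a 1.2-fold lower number from compound 2 to compound 3 (0.07 log units; within the scatter), which alters the group on the same carbon and stays within the scatter. The steps of an at least 6.3-fold lower number from compound 1 to compound 2 (0.80 log units; beyond the scatter) and an at least 7.5-fold lower number from compound 1 to compound 3 (0.87 log units; beyond the scatter) are larger, but they are bounds set against the limit of > 3000 nM in this assay, at which 1 of the 3 values shown sits, and they exchange a bigger piece of the molecule, so they bear less on this change. Among the measured compounds shown here, the one close precedent therefore points to no shift beyond the scatter in this assay, and the data give no firm direction.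

The expected step is a 1.1-fold higher number from compound 3 to compound 4 (0.05 log units; within the scatter). For compound 4 the estimated value is 450 nM, with an expected range of 180 nM to 1100 nM.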

Compound 4, half-maximal inhibitory concentration: > 3000 nM
Compound 4: a limit, no number (the forecaster's own chance of this, stated with the estimate: 8%); middle value at least 6.6-fold (0.82 log units) from the limit.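

Working notes on the group on the saturated chain carbon bound to an oxygen on an aromatic ring: in this assay this position does not accept every aromatic group, as thiophen-2-yl in place of pyrazin-2-yl gives an at least 7.5-fold higher number from compound 3 to compound 4 (0.87 log units; beyond the scatter). Thiophen-2-yl in place of 1-(pyridin-2-yl)ethyl gives an at least 6.3-fold higher number from compound 2 to compound 4 (0.80 log units; beyond the scatter), while the exchange of the two nitrogen-bearing groups, a 1.2-fold lower number from compound 2 to compound 3 (0.07 log units; within the scatter), stays within the scatter, so among compounds 2, 3 and 4 a ring nitrogen in this group goes with a measurable number and the sulfur ring with a limit. Compound 1 goes against any wider reading of this pattern: it carries a quinoline nitrogen in its 2-(quinolin-2-yl)ethyl group and also gives only a limit, > 3000 nM.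

The step from compound 1 to compound 4 cannot be read, and the two cannot be ranked against each other: the limit of > 3000 nM in this assay, at which 2 of the 4 values shown sit.

Still open, from the compounds shown here alone, is whether the ring nitrogen, the sulfur or the five-membered ring decides the outcome, a question that phenyl, pyridin-2-yl or thiazol-2-yl on the same carbon would help to separate.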